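Dropping both methoxy groups from the ethenyl-linked phenyl

The source may report more compounds than this note shows. Statements on the series, on what has been measured and on what is new or still open speak of the compounds shown alone.

Measured compounds in a functional assay on MCF7 cells (Homo sapiens) for antiproliferative activity, read by MTT assay, with a stated time of 72 h; a higher number here means a weaker inhibitor, a lower number a stronger inhibitor:
compound 1 `COc1cc(/C=C/c2ccc(C3=C(c4ccc(O)cc4)C4CC(S(=O)(=O)Oc5ccccc5)C3O4)cc2)cc(OC)c1`: compound 1 sits at > 100000 nM, a limit of the assay.
compound 2 `COc1cc(/C=C/c2ccc(C3=C(c4ccc(O)cc4)C4CC(S(=O)(=O)Oc5ccc(Br)cc5)C3O4)cc2)cc(OC)c1`: compound 2 sits at > 100000 nM, again a limit of the assay.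
compound 3 `CCc1ccccc1OS(=O)(=O)C1CC2OC1C(c1ccc(/C=C/c3cc(OC)cc(OC)c3)cc1)=C2c1ccc(O)cc1`: compound 3 gives 49800 nM.

Compound 1 stands only as a limit, and two of the three values shown share that limit (the limit of > 100000 nM in this assay, at which 2 of the 3 values shown sit). The steps measured so far, a step that the two limits leave unreadable from compound 1 to compound 2, an at least 2.0-fold lower number from compound 1 to compound 3 (0.30 log units; that floor lies within the scatter) and an at least 2.0-fold lower number from compound 2 to compound 3 (0.30 log units; that floor lies within the scatter), all alter the aryl on the sulfonate oxygen and leave the ethenyl-linked phenyl untouched.

Compound 4 `O=S(=O)(Oc1ccccc1)C1CC2OC1C(c1ccc(/C=C/c3ccccc3)cc1)=C2c1ccc(O)cc1` differs from compound 1 in that arm: phenyl in place of 3,5-dimethoxyphenyl on a double-bonded chain carbon bound to a double-bonded chain carbon. Among the measured compounds shown here, no measured step bears on this change, so the expectation rests on compound 1 alone, which sits at the limit > 100000 nM. The step from compound 1 to compound 4 is therefore expected to stay within the scatter, a number no higher from compound 1 to compound 4 (the limit leaves the size open). Compound 4 is estimated at 100000 nM, with a range from 30000 nM to 300000 nM, and most likely the assay again reports only a limit.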

Compound 4, half-maximal inhibitory concentration: 25200 nM
For compound 4 the middle estimate is 4.0-fold (0.60 log units) above the measured one; the measured number lies below the stated range.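

In this assay, phenyl in place of 3,5-dimethoxyphenyl gives an at least 3.9-fold lower number from compound 1 to compound 4 (0.59 log units; beyond the scatter). Among the compounds shown here, this is the first step that lies beyond the scatter: the earlier changes, all to the aryl on the sulfonate oxygen, either cannot be read or have floors within the scatter, so the ethenyl-linked arm now stands as a position where a change registers in this assay. The full size of the step stays unknown because compound 1 rests on a limit: the limit of > 100000 nM in this assay, at which 2 of the 4 values shown sit.

On these data alone, whether the same change would carry over with 2-ethylphenyl or 4-bromophenyl on the sulfonate oxygen remains open, since compound 2 and compound 3 both keep the 3,5-dimethoxyphenyl arm. Also open, as far as these compounds go, is how a single methoxy, a hydroxyl or an amine on that phenyl would read.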